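Dihydrobenzofuran for methylphenyl on a benzimidazole acid

A few compounds are considered here, and "the series" means these few. Any claim that something is new, unique, unknown or untested is made for them only; others in the source may bear on it.

The series is read in an assay on isolated protein for inhibition of Long-chain-fatty-acid--CoA ligase 1 (Mus musculus), read by mass spectrometry, with a stated time of 90 min, in the presence of a further agent that is not named here; a higher number here means a weaker inhibitor, a lower number a stronger inhibitor. Three compounds carry numbers. Compound 1 `O=C(O)[C@H]1CC[C@@H](Oc2ccc3oc(-c4ccccc4)nc3c2)CC1` gives 59000 nM. Compound 2 `Cc1cccc(Cc2nc3cc(O[C@H]4CC[C@@H](C(=O)O)CC4)ccc3n2C)c1` gives 30 nM, the lowest number of the three, and the gaps from it to compound 1 and to compound 3 both lie beyond the usual scatter. Compound 3 `Cc1cccc(Cc2c(C#N)c3cc(O[C@H]4CC[C@@H](C(=O)O)CC4)ccc3n2C)c1` gives 600 nM.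

Compound 4 `Cn1c(Cc2ccc3c(c2)OCC3)nc2cc(O[C@H]3CC[C@@H](C(=O)O)CC3)ccc21` has not been measured. It differs from compound 2 in one place: a group of 9 heavy atoms (8 carbon, 1 oxygen; one five-membered non-aromatic ring with 1 hetero atom, one six-membered aromatic ring of carbon only) in place of a group of 7 heavy atoms (7 carbon; one six-membered aromatic ring of carbon only), on a saturated chain carbon bound to an aromatic carbon. Among the measured compounds shown here, no measured pair in this set shows what such a change does, so the expectation rests on compound 2 alone, whose value of 30 nM marks the starting point. The shared core, the acid-bearing ring and the position of the benzylic attachment are unchanged, so the author expects compound 4 to stay close to compound 2, with a step from compound 2 to compound 4 of a 1.7-fold higher number from compound 2 to compound 4 (0.22 log units; within the scatter) that may not exceed the scatter. Compound 4 is therefore estimated at 50 nM, with a range from 15 nM to 200 nM.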

Compound 4, half-maximal inhibitory concentration: 36 nM
The estimate for compound 4 lay 1.4-fold (0.14 log units) above the measured number; the range from low to high includes it.
By their numbers in this assay, from the lowest: compounds 2 and 4 (each within the scatter of the next); then compound 3; then compound 1.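

In this assay, among the compounds shown here, the step of a 1.2-fold higher number from compound 2 to compound 4 (0.08 log units; within the scatter) is the first one-place comparison in this set. It shows that, on a saturated chain carbon bound to an aromatic carbon, the group of 9 heavy atoms with its five-membered non-aromatic ring and one hydrogen-bond acceptor can take the place of 3-methylphenyl with no difference beyond the scatter, so compound 2 and compound 4 cannot be told apart here. No measurement shown here offers a reason for this result.

Still open, on these data alone, is whether this place accepts anything other than these two ring groups, such as a phenyl ring carrying an amine or a carboxylic acid, or a longer chain in place of the saturated chain carbon. Also open, as far as these compounds go, is whether the ring oxygen counts at all, which a five-membered ring of carbon only would test.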